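A few compounds are considered here, and "the series" means these few. Any claim that something is new, unique, unknown or untested is made for them only; others in the source may bear on it.

Compound 3 `CNC1=NS(=O)(=O)c2cc(Cl)ccc2N1` is the starting point of this step. In a functional assay (aorta) with Rattus norvegicus as the target (a lower number here means that less compound is needed, a higher number that more compound is needed for the effect), compound 3 gives 142 uM, the highest of the two numbers that this series has so far produced. Compound 2 `O=S1(=O)NC(NC2CCCC2)=Nc2ccc(F)cc21`, which carries a cyclopentyl group on the amine nitrogen and a fluoro substituent on the ring, gives 58 uM in this assay, a lower number than compound 3. Compound 1 `CNC1=NS(=O)(=O)c2cc(F)ccc2N1` gives only a limit of the assay, > 300 uM in this assay, so that the limit of > 300 uM in this assay, at which 1 of the 3 values shown sits, marks the point past which it could not be measured. Between compound 1 and compound 3 the change was chloro in place of fluoro on an aromatic carbon, and the number moved by an at least 2.1-fold lower number from compound 1 to compound 3 (0.32 log units; beyond the scatter).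

Compound 4 `O=S1(=O)N=C(NC2CCC2)Nc2ccc(Cl)cc21` keeps the chloro substituent of compound 3 and changes only the group on the amine nitrogen: cyclobutyl in place of methyl on an amine nitrogen.

Within the data shown here, no measured step covers exactly this change. Among the measured compounds shown here, the only hint comes from compound 2, whose larger ring on the amine nitrogen goes with a lower number than compound 3 shows. A modest downward step is therefore expected, a 3.2-fold lower number from compound 3 to compound 4 (0.50 log units; beyond the scatter), and compound 4 is estimated to give 45 uM in this assay, within a range from 15 uM to 140 uM.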

Compound 4, concentration for half-maximal effect: 34.9 uM
Compound 4: the middle estimate sits 1.3-fold (0.11 log units) above what was measured; measured number inside the range.
By their numbers in this assay, from the lowest: compounds 4 and 2 (each within the scatter of the next); then compound 3. At a limit, above all of these: compound 1.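

Among these compounds, the step from methylamino to cyclobutylamino is the first reading of a change at the amine nitrogen with the rest of the molecule held constant: it gives a 4.1-fold lower number from compound 3 to compound 4 (0.61 log units; beyond the scatter) in this assay. Among the compounds shown here, until now, the only step that could be read lay on an aromatic carbon, so this result adds a second place in the molecule where one change moves the number beyond the scatter. Nothing measured here shows why replacing a methyl with a cyclobutyl lowers the number.

On these data alone, a single pair cannot show a trend, so it stays open whether the number would keep falling with other groups on this nitrogen, such as a longer chain like butyl or a ring carrying an amine. As far as these compounds go, whether cyclobutyl in place of methyl gives a step of similar size with fluoro instead of chloro on the ring also stays open: compound 1, the fluoro compound with the methyl group, has only a limit, > 300 uM, and no exact step can be read from it.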